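Shortening the phenoxyalkyl chain on the aromatic nitrogen

A few compounds are considered here, and "the series" means these few. Any claim that something is new, unique, unknown or untested is made for them only; others in the source may bear on it.

Compound 1 `CCCn1c(-c2ccc(O)c(O)c2)c(C)c2cc(O)ccc21` gives in a functional assay on MSTO-211H cells (Homo sapiens) for inhibition, read by trypan blue exclusion, with a stated time of 72 h (on this read-out higher numbers stand for weaker inhibition of growth and lower numbers for stronger inhibition of growth), only a limit, > 20000 nM.
Compound 2 `Cc1c(-c2ccc(O)c(O)c2)n(CCCCOc2ccccc2)c2ccc(O)cc12` gives in this assay 3400 nM.

Within the data shown here, compound 2 holds the only number recorded in this assay. The value for compound 1 is a limit. Compound 3 `Cc1c(-c2ccc(O)c(O)c2)n(CCCOc2ccccc2)c2ccc(O)cc12` differs from compound 2 by phenoxy in place of phenoxymethyl on a saturated chain carbon, three bonds along the chain from an aromatic nitrogen. Among the measured compounds shown here, the single measured step, an at least 5.8-fold lower number from compound 1 to compound 2 (0.76 log units; beyond the scatter), ran toward stronger inhibition when phenoxymethyl entered, though it rests on the limit (the limit of > 20000 nM in this assay, at which 1 of the 2 values shown sits). Compound 3 keeps the phenoxy group on a shorter chain, so the expected change is small: a 1.2-fold higher number from compound 2 to compound 3 (0.07 log units; within the scatter). Compound 3 is therefore estimated at 4000 nM, expected between 1500 nM and 12000 nM.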

Compound 3, concentration for 50% growth inhibition: 7100 nM
Compound 3: middle estimate off by 1.8-fold (0.25 log units), on the low side; the measured number falls inside the stated range.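

In this assay the length of the chain carrying the phenoxy group counts: a 2.1-fold higher number from compound 2 to compound 3 (0.32 log units; beyond the scatter), so the shorter chain of compound 3 gives up part of what compound 2 gained. Even so, phenoxy on the shorter chain still leaves an at least 2.8-fold lower number from compound 1 to compound 3 (0.44 log units; beyond the scatter). That step rests on the limit of compound 1: the limit of > 20000 nM in this assay, at which 1 of the 3 values shown sits.

As far as these compounds go, whether a chain longer than that of compound 2 lowers the number further stays open. So does whether an amine or a carboxylic acid can stand in place of the phenoxy group.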